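A few compounds are considered here, and "the series" means these few. Any claim that something is new, unique, unknown or untested is made for them only; others in the source may bear on it.

Working notes, this series. In an ADME assay on microsomes from liver (Mus musculus) for metabolic stability, read by HPLC, using NADPH, with a stated time of 60 min, tested at 1 uM, in the presence of a further agent that is not named here (a lower number here means that the compound disappears faster, a higher number that the compound lasts longer), compound 2 `O=C(NNS(=O)(=O)c1ccccc1F)c1cccc(-n2cccn2)c1` holds the highest number of the three with 0.167 h; compound 3 `Cc1cc(-n2cccn2)cc(C(=O)NNS(=O)(=O)c2ccccc2)c1F` gives 0.05 h and compound 1 `Cc1cc(-n2nccn2)cc(C(=O)NNS(=O)(=O)c2ccccc2)c1F` gives 0.0333 h, both gaps lying beyond the scatter. Going by the values given here, the single one-place step recorded, a 1.5-fold higher number from compound 1 to compound 3 (0.18 log units; within the scatter), is within the scatter.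

Compound 4 `O=C(NNS(=O)(=O)c1ccccc1F)c1cc(F)cc(-n2cccn2)c1` is the next case, derived from compound 2 by one change: fluoro in place of hydrogen on an aromatic carbon.

Among the compounds with values here, no measured pair in this set exchanges hydrogen for fluoro, and the only step at hand, a 1.5-fold higher number from compound 1 to compound 3 (0.18 log units; within the scatter), concerns a different group and is itself within the scatter, so it offers no direction. The expectation is therefore a step of no size beyond the scatter, no change at the digits printed from compound 2 to compound 4 (within the scatter). Compound 4 is estimated at 0.167 h, in the range 0.08 h to 0.35 h.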

Compound 4, half-life in the Mus musculus assay: 0.0833 h
Compound 4: the middle estimate sits 2.0-fold (0.30 log units) above what was measured; the range from low to high includes it.
By their numbers in the Mus musculus assay, from the lowest: compounds 1, 3, 4 and 2 (each within the scatter of the next, the first and the last beyond it).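

Fluoro in place of hydrogen on this aromatic carbon, meta to a 1H-pyrazol-1-yl group, now has its first reading in the series: in the Mus musculus assay the change gives a 2.0-fold lower number from compound 2 to compound 4 (0.30 log units; within the scatter) and so does not separate the pair. In a physicochemical assay for solubility, read by nephelometry, in phosphate buffer, measured as kinetic solubility, at pH 6.5 (on this read-out higher numbers stand for higher solubility and lower numbers for lower solubility), compound 2 gives 50 ug/mL and compound 4 gives 25 ug/mL within the scatter of each other. Nothing at hand bears on why the numbers stand where they do.

As far as these compounds go, whether chloro, methoxy or an amine on the same carbon would give a step beyond the scatter on either read-out stays open.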